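Compound 4 after the furan-2-yl limit

A few compounds are considered here, and "the series" means these few. Any claim that something is new, unique, unknown or untested is made for them only; others in the source may bear on it.

compound 1 `O=C(N/N=C/c1ccc(F)cc1)N1CCc2ncnc(Nc3cccc(Br)c3)c2C1`: 37600 nM
compound 2 `O=C(N/N=C/c1cccs1)N1CCc2ncnc(Nc3cccc(Br)c3)c2C1`: 122000 nM
compound 3 `O=C(N/N=C/c1ccco1)N1CCc2ncnc(Nc3cccc(Br)c3)c2C1`: > 200000 nM (a limit)

In a functional assay on NCI-H1975 cells (Homo sapiens) for cytotoxicity, read by MTT assay, with a stated time of 72 h (on this read-out lower numbers stand for stronger inhibition and higher numbers for weaker inhibition), compound 3 gives > 200000 nM, and this is a limit of the assay, not a number. Compound 4 `O=C(N/N=C/c1cccnc1)N1CCc2ncnc(Nc3cccc(Br)c3)c2C1` differs from compound 3 at one place: pyridin-3-yl in place of furan-2-yl on a carbon with a double bond to nitrogen. Pyridin-3-yl stands in place of furan-2-yl on a carbon with a double bond to nitrogen.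

The measured steps all exchange the group at this same carbon. Thiophen-2-yl in place of 4-fluorophenyl gave a 3.2-fold higher number from compound 1 to compound 2 (0.51 log units; beyond the scatter). Furan-2-yl in place of 4-fluorophenyl gave an at least 5.3-fold higher number from compound 1 to compound 3 (0.72 log units; beyond the scatter). Furan-2-yl in place of thiophen-2-yl gave an at least 1.6-fold higher number from compound 2 to compound 3 (0.21 log units; that floor lies within the scatter). Pyridin-3-yl is a six-membered aromatic ring, as is the 4-fluorophenyl of compound 1, which gives 37600 nM, and thiophen-2-yl in compound 2 gives 122000 nM. A modest step to a lower number in this assay is therefore expected, though a second limit remains possible. The expected change is an at least 2.2-fold lower number from compound 3 to compound 4 (0.34 log units; beyond the scatter). Compound 4 is estimated at 90000 nM, with an expected range of 30000 nM to 200000 nM.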

Compound 4, half-maximal inhibitory concentration: > 200000 nM
Compound 4: a limit, no number; the forecaster's own chance of this, stated with the estimate: 30%; middle value at least 2.2-fold (0.34 log units) away from the limit.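

In this assay compound 4 gives > 200000 nM, which is a limit of the assay and not a number. A six-membered aromatic ring at this carbon with a double bond to nitrogen therefore does not by itself keep the reading of compound 1, as pyridin-3-yl gives an at least 5.3-fold higher number from compound 1 to compound 4 (0.72 log units; beyond the scatter), whereas an at least 1.6-fold higher number from compound 2 to compound 4 (0.21 log units; that floor lies within the scatter) leaves pyridin-3-yl and thiophen-2-yl unordered. The step between compound 3 and compound 4 cannot be read because both stand at the same limit: the limit of > 200000 nM in this assay, at which 2 of the 4 values shown sit.

The compounds shown leave open whether the reading of compound 1 depends on the fluorine or on the phenyl ring itself, which unsubstituted phenyl or 4-chlorophenyl at this carbon would address. They also leave open whether an amine or a carboxylic acid on the pyridin-3-yl ring would bring a reading inside the limit.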